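Trading Methylcarbamoyl for Acetoxymethyl on a Side Chain

This account rests on a few compounds, and the source may have more. Where it says the series, first, only, none or still open, it means among the compounds named here.

Of the compounds shown here, two sharing one core have been measured in a functional assay on HCT-116 cells (Homo sapiens) for antiproliferative activity, read by sulforhodamine B assay, with a stated time of 72 h; a lower number here means a stronger inhibitor, a higher number a weaker inhibitor. Compound 1 (`Cn1ncc(Cl)c1-c1cc(C(=O)N[C@@H]2CN[C@H](CC(O)CO)C[C@H]2c2ccc(F)c(F)c2)oc1Cl`) gives 800 nM, and compound 2 (`CNC(=O)C[C@@H]1C[C@@H](c2ccc(F)c(F)c2)[C@H](NC(=O)c2cc(-c3c(Cl)cnn3C)c(Cl)o2)CN1`) gives 1100 nM. These values lie within the scatter of each other, so compound 2 cannot be told apart from compound 1 on these numbers.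

Compound 3 (`CC(=O)OCC[C@@H]1C[C@@H](c2ccc(F)c(F)c2)[C@H](NC(=O)c2cc(-c3c(Cl)cnn3C)c(Cl)o2)CN1`) departs from compound 2 in one place, with acetoxymethyl in place of methylcarbamoyl on a saturated chain carbon bound to a saturated ring carbon.

Among the compounds with values here, only one measured step bears on this change. It is a 1.4-fold higher number from compound 1 to compound 2 (0.14 log units; within the scatter), and it came from methylcarbamoyl taking the place of 1,2-dihydroxyethyl at the same carbon. Within the data shown here, one small step is thin evidence, and no compound measured so far carries acetoxymethyl, so the data point in no direction. In this assay, a change beyond the scatter is therefore not expected. The expected step is a 1.1-fold lower number from compound 2 to compound 3 (0.04 log units; within the scatter). For compound 3 the estimated value is 1000 nM, with an expected range from 350 nM to 3000 nM.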

Compound 3, half-maximal inhibitory concentration: 690 nM
For compound 3 the middle estimate is 1.4-fold (0.16 log units) above the measured one, and the stated range covers the measured number.
By their numbers in this assay, from the lowest: compounds 3, 1 and 2 (each within the scatter of the next).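

In this assay, acetoxymethyl in place of methylcarbamoyl on a saturated chain carbon bound to a saturated ring carbon gives a 1.6-fold lower number from compound 2 to compound 3 (0.20 log units; within the scatter), and acetoxymethyl in place of 1,2-dihydroxyethyl at that same carbon gives a 1.2-fold lower number from compound 1 to compound 3 (0.06 log units; within the scatter). Both steps stay within the scatter, so three differently built side chains now give numbers that cannot be told apart, and the exchange that removes the one hydrogen-bond donor of methylcarbamoyl, leaving none in acetoxymethyl, does not register as a real difference in this read-out. Nothing available here explains why the three numbers stay so close together.

Within the data shown here, no step at this carbon yet goes beyond the scatter. The compounds shown do not reveal what kind of group, if any, would make the number clearly higher or lower. A primary amine, a carboxylic acid or a longer chain at the same carbon would test whether this insensitivity holds beyond these three side chains, or whether it is limited to neutral groups of about this size.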